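Nitrophenyl shift from compound 2 to compound 4

A few compounds are considered here, and "the series" means these few. Any claim that something is new, unique, unknown or untested is made for them only; others in the source may bear on it.

Measured in a functional assay on HL-60 cells (Homo sapiens) for inhibition, read by CCK-8 assay, with a stated time of 48 h; a higher number here means a weaker inhibitor, a lower number a stronger inhibitor:
- compound 1 `O=S(=O)(NCCNC(=S)Nc1cc(C(F)(F)F)cc(C(F)(F)F)c1)c1cc(-c2ccccc2Oc2ccc(O)c(O)c2)cs1` gives 600 nM
- compound 2 `Cc1ccc(-c2ccsc2S(=O)(=O)NCCNC(=O)Nc2ccc([N+](=O)[O-])cc2)c(Oc2ccc(O)c(O)c2)c1` gives 3900 nM
- compound 3 `O=C(NCCNS(=O)(=O)c1cc(-c2ccccc2Oc2ccc(O)c(O)c2)cs1)Nc1cc(Cl)cc(Cl)c1` gives > 20000 nM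

For compound 3 the entry > 20000 nM is a limit of the assay, not a number.

Of the two numerical results, compound 1 gives 600 nM and compound 2 has the higher number at 3900 nM, a gap beyond the usual scatter.

Compound 4 `Cc1ccc(-c2ccsc2S(=O)(=O)NCCNC(=O)Nc2cccc([N+](=O)[O-])c2)c(Oc2ccc(O)c(O)c2)c1` differs from compound 2 as follows: 3-nitrophenyl in place of 4-nitrophenyl on an amide-type nitrogen, with 3-nitrophenyl in place of 4-nitrophenyl on an amide-type nitrogen.

Going by the values given here, no measured pair isolates this change. No step beyond the scatter is expected in this assay, in either direction. The expected change is a 1.0-fold higher number from compound 2 to compound 4 (0.01 log units; within the scatter).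

Compound 4 is estimated at 4000 nM, with an expected range from 1300 nM to 12000 nM.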

Compound 4, half-maximal inhibitory concentration: 6000 nM
For compound 4 the middle estimate is 1.5-fold (0.18 log units) below the measured one; the range from low to high includes it.
By their numbers in this assay, from the lowest: compound 1; then compounds 2 and 4 (each within the scatter of the next). At a limit, above all of these: compound 3.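

In this assay, going by these compounds alone, 3-nitrophenyl in place of 4-nitrophenyl on an amide-type nitrogen gives a 1.5-fold higher number from compound 2 to compound 4 (0.19 log units; within the scatter), the first step that isolates a single change. The two nitrophenyl isomers are therefore not told apart in this assay, so activity at this position does not depend on which of these two isomers is present. Nothing measured here bears on this result.

Still open, going by these compounds, is how 2-nitrophenyl would read at this position. Also open, on these data alone, is whether an amine or a carboxylic acid in place of the nitro group would stay within the same range.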